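The compounds below may be only part of what the source reports. "The series", "measured", "known", "first", "only" and "open" are said of these compounds alone.

Measured so far in a functional assay on the whole organism (Tail, strain ICR) with Mus musculus as the target, in the tail flick test, with a stated time of 90 min, at a dose of 25 umol/kg by the oral route; a lower number here means a weaker effect, a higher number a stronger effect of the compound at the dose given:
Compound 1, `NCCCC[C@H](NC(=O)CN(c1nc(Cl)nc2[nH]cnc12)C1CC1)C(=O)O`, gives 28.8%.
Compound 2, `CC(C)[C@H](NC(=O)CN(c1nc(Cl)nc2[nH]cnc12)C1CC1)C(=O)O`, gives 30.3%.
Compound 3, `CSCC[C@H](NC(=O)CN(c1nc(Cl)nc2[nH]cnc12)C1CC1)C(=O)O`, gives 14%.

All three share the same core and differ only in the side chain on the saturated chain carbon bound to an amide-type nitrogen and a carbonyl carbon. Compound 3 stands lowest of the three, beyond the scatter below both of the others, while compound 1 and compound 2 sit within the scatter of each other, as a number 1.5 percentage points higher from compound 1 to compound 2 (within the scatter) shows.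

The next compound, compound 4, `CC(C)C[C@H](NC(=O)CN(c1nc(Cl)nc2[nH]cnc12)C1CC1)C(=O)O`, differs from compound 3 by isopropyl in place of (methylsulfanyl)methyl on a saturated chain carbon, two bonds along the chain from an amide-type nitrogen and a carbonyl carbon. Among the measured compounds shown here, the steps that bear on this are those leading into compound 3: a number 14.8 percentage points lower from compound 1 to compound 3 (beyond the scatter) and a number 16.3 percentage points lower from compound 2 to compound 3 (beyond the scatter). In both, exchanging a side chain without sulfur for the sulfur-bearing one went with a modest drop. Compound 4 removes the sulfur again and carries a branched alkyl side chain, isobutyl, close in kind to the isopropyl of compound 2. A modest step upward in this assay is therefore expected, a number 14 percentage points higher from compound 3 to compound 4 (beyond the scatter), bringing compound 4 back near compound 1 and compound 2. The estimate for compound 4 is 28%, with a range from 16% to 40%.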

Compound 4, a percentage reported as activity, at one dose (the size of the read-out at that dose, not a potency): 27%
Beside the measured number, compound 4's estimate is 1 percentage points above it, within the range that was stated.
By their numbers in this assay, from the lowest: compound 3; then compounds 4, 1 and 2 (each within the scatter of the next).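

In this assay, a number 13 percentage points higher from compound 3 to compound 4 (beyond the scatter) when isopropyl takes the place of (methylsulfanyl)methyl on a saturated chain carbon, two bonds along the chain from an amide-type nitrogen and a carbonyl carbon. Unlike the earlier steps, this one swaps groups of 3 heavy atoms each, with a carbon in place of the sulfur, so the side chain keeps its size in heavy atoms while the number still moves beyond the scatter. The other two steps stay within the scatter, a number 3.3 percentage points lower from compound 2 to compound 4 (within the scatter) and a number 1.8 percentage points lower from compound 1 to compound 4 (within the scatter), so among the compounds shown only the sulfur-bearing side chain of compound 3 stands apart, and no measurement offered here explains why.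

The compounds shown leave open whether the low number follows the sulfur atom itself or the unbranched shape of the 2-(methylsulfanyl)ethyl chain, a question that a straight butyl chain at this position would address. They also leave open how this position responds to side chains of other kinds, such as a benzyl group or a chain ending in a carboxylic acid.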